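This account rests on a few compounds, and the source may have more. Where it says the series, first, only, none or still open, it means among the compounds named here.

Compound 1 `Cc1[nH]c2ccc(Br)cc2c1C1=CCNCC1` is the more potent of the two measured compounds in an assay on HEK293 cells for displacement of a labelled ligand from 5-hydroxytryptamine receptor 6 (Homo sapiens), read by scintillation counting, with a stated time of 1 h (on this read-out higher numbers stand for weaker inhibition and lower numbers for stronger inhibition), where compound 1 gives 10 nM. Its partner compound 2 `Cc1[nH]c2ccc(F)cc2c1C1=CCNCC1` gives 30 nM in this assay, a 3.0-fold higher number from compound 1 to compound 2 (0.48 log units; beyond the scatter). The unmeasured compound 3 `Cc1[nH]c2ccccc2c1C1=CCNCC1` differs from compound 1 by hydrogen in place of bromo on an aromatic carbon. Within the data shown here, the one relevant step, from bromo to fluoro, already weakened binding modestly; removing the halogen altogether seems likely to weaken it at least as much. Compound 3 is therefore expected to give about 40 nM, between 15 nM and 120 nM, an expected 4.0-fold higher number from compound 1 to compound 3 (0.60 log units; beyond the scatter) in this assay.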

Compound 3, half-maximal inhibitory concentration: 200 nM
The estimate for compound 3 lay 5.0-fold (0.70 log units) below the measured number; measured number above the stated range.
By their numbers in this assay, from the lowest: compound 1; then compound 2; then compound 3.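

Both halogens on this aromatic carbon give lower numbers than hydrogen in this assay: losing the bromo gives a 20-fold higher number from compound 1 to compound 3 (1.30 log units; beyond the scatter), and losing the fluoro gives a 6.7-fold higher number from compound 2 to compound 3 (0.82 log units; beyond the scatter). The earlier swap of one halogen for the other was therefore the smaller part of what this position can change, and the order here runs bromo, fluoro, hydrogen. Nothing measured here explains why the halogens differ from hydrogen.

Going by these compounds, whether chloro would match bromo remains open, as does whether a methoxy group or a nitrile at this place would do as well as a halogen.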